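The compounds below may be only part of what the source reports. "The series", "measured", "known", "first", "only" and "open" are said of these compounds alone.

Two close relatives share one core, differing only at a saturated ring carbon of the six-membered non-aromatic ring and at the urea or thiourea within it. Compound 1 `COc1cc(/C=C/C(=O)C2=C(/C=C/c3ccc(O)c(OC)c3)NC(=O)NC2c2c(Cl)cccc2Cl)ccc1O` and compound 2 `COc1cc(/C=C/C(=O)C2=C(/C=C/c3ccc(O)c(OC)c3)NC(=S)NC2c2ccc(C)cc2)ccc1O` were both tested in a functional assay, with a stated time of 20 min, tested at 2 uM; a higher number here means a stronger effect of the compound at the concentration tested, a lower number a weaker effect. Compound 1 gives 11.2%, and compound 2 gives 10.2%. These two figures lie within the usual scatter of each other, so the data do not separate them.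

The next step moves from compound 2 to compound 3 `COc1cc(/C=C/C(=O)C2=C(/C=C/c3ccc(O)c(OC)c3)NC(=S)NC2c2ccccc2Cl)ccc1O`. The change is 2-chlorophenyl in place of 4-methylphenyl on a saturated ring carbon. Among the measured compounds shown here, no pair of measured compounds shows a step of this kind, so there is no measured precedent for it. Compound 1, which carries a different chlorinated ring at the same saturated carbon, gives a figure close to that of compound 2, which suggests that swapping one such ring for another at this position leaves the effect roughly where it is.

Compound 3 is therefore expected to give about 12% in this assay, within a range of 4% to 22%. The expected step, a number 1.8 percentage points higher from compound 2 to compound 3 (within the scatter), would stay inside the scatter, with no direction beyond it.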

Compound 3, a percentage reported as activity, at one concentration (the size of the read-out at that concentration, not a potency): 15.5%
The estimate for compound 3 lay 3.5 percentage points below the measured number; measured number inside the range.
By their numbers in this assay, from the lowest: compounds 2, 1 and 3 (each within the scatter of the next).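

Exchanging 4-methylphenyl for 2-chlorophenyl on the saturated ring carbon, with the thiourea and the rest of the core held fixed, gives in this assay a number 5.3 percentage points higher from compound 2 to compound 3 (within the scatter), so the data do not separate the two compounds. Among the compounds shown here, this is the first direct comparison at this position, and it shows that replacing a methyl-bearing phenyl ring with a chlorine-bearing one, both six-membered aromatic rings of carbon only, does not move the read-out beyond the usual scatter at the single concentration tested. Nothing available explains the size of this step, nor does any information on the properties of the two groups bear on it.

The compounds shown all carry a substituted phenyl ring at this carbon, so it remains open whether a ring bearing an amine or a carboxylic acid, or a non-aromatic group such as cyclohexyl or a longer alkyl chain, would shift the effect beyond the scatter. It is also open whether 2-chlorophenyl would give a similar number with the urea in place of the thiourea, since no pair shown isolates that exchange.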